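Swapping tert-butyl for phenethyl on a triple-bonded carbon

A few compounds are considered here, and "the series" means these few. Any claim that something is new, unique, unknown or untested is made for them only; others in the source may bear on it.

- Compound 1 `Cn1cncc1C(OCc1ccc(C#N)cc1C#Cc1ccc(-c2ccccc2)cc1)c1ccc(C#N)cc1`: > 0.1 nM
- Compound 2 `Cn1cncc1C(OCc1ccc(C#N)cc1C#CC(C)(C)C)c1ccc(C#N)cc1`: 76.9 nM

Going by the values given here, in a functional assay on NIH3T3 cells (Mus musculus) (on this read-out higher numbers stand for an effect only at larger amounts of compound and lower numbers for an effect already at smaller amounts), compound 2 gives 76.9 nM, the only true number so far. Compound 1 offers just a limit, not a number. The next molecule, compound 3 `Cn1cncc1C(OCc1ccc(C#N)cc1C#CCCc1ccccc1)c1ccc(C#N)cc1`, keeps the rest of compound 2 and changes one group, with phenethyl in place of tert-butyl on a triple-bonded carbon. Among the compounds with values here, the one measured step at this place is a step that the limit leaves unreadable from compound 1 to compound 2, so it supplies no size to carry over. All that stands behind it is the limit of > 0.1 nM in this assay, at which 1 of the 2 values shown sits. The expectation therefore rests on compound 2 and its 76.9 nM, with no shift in either direction expected beyond the usual scatter, though the uncertainty is wide. The expected change is a 1.3-fold lower number from compound 2 to compound 3 (0.11 log units; within the scatter). For compound 3 the estimated value is 60 nM, with an expected range from 12 nM to 300 nM.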

Compound 3, half-maximal effective concentration: 130 nM
Compound 3: the middle estimate sits 2.2-fold (0.34 log units) below what was measured, within the range that was stated.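

In this assay, putting phenethyl in place of tert-butyl on the triple-bonded carbon gives a 1.7-fold higher number from compound 2 to compound 3 (0.23 log units; within the scatter). So at this position, a group with a six-membered aromatic ring of carbon only and a group with no ring give values that cannot be told apart in this assay. This holds for this one pair only, and the two groups share the absence of hydrogen-bond donors, hydrogen-bond acceptors and net charge. For compound 1 there is only a limit, so the steps from it cannot be read: the limit of > 0.1 nM in this assay, at which 1 of the 3 values shown sits.

The compounds shown leave open whether a chain carrying an amine or a carboxylic acid on this triple-bonded carbon would stay in the same range. They also leave open whether a longer chain ending in the same ring would do so.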